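The source may hold more compounds than are shown below. What is called first, only, known or untested is meant among the compounds shown, and "the series" means these compounds.

Of the compounds shown here, two have been measured in an assay on tissue (HeLa cells) for inhibition of Indoleamine 2,3-dioxygenase 1 (Homo sapiens), read by spectrophotometry; on this read-out higher numbers stand for weaker inhibition and lower numbers for stronger inhibition. Compound 1, `OCc1cc2cc(/C(=N\O)Nc3cccc(Br)c3)ccc2o1`, gives 1200 nM in that assay. Compound 2, `O/N=C(/Nc1cccc(F)c1)c1ccc2oc(-c3ccccc3)cc2c1`, gives 10600 nM and so stands at the higher of the two numbers, compound 1 sitting an order below it. Compound 3, `O/N=C(/Nc1cccc(Br)c1)c1ccc2oc(-c3ccccc3)cc2c1`, differs from compound 2 by bromo in place of fluoro on an aromatic carbon. For the measured compounds named here, with no comparable pair measured, the step from compound 2 to compound 3 is expected to be small, toward stronger inhibition if anything, and estimated as a 2.1-fold lower number from compound 2 to compound 3 (0.33 log units; beyond the scatter). Compound 3 is therefore estimated to give about 5000 nM, within a range from 1500 nM to 15000 nM.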

Compound 3, half-maximal inhibitory concentration: 8600 nM
Beside the measured number, compound 3's estimate is 1.7-fold (0.24 log units) below it, and the stated range covers the measured number.
By their numbers in this assay, from the lowest: compound 1; then compounds 3 and 2 (each within the scatter of the next).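

In this assay, bromo in place of fluoro on the aromatic carbon meta to a large group gives a 1.2-fold lower number from compound 2 to compound 3 (0.09 log units; within the scatter), so with phenyl on the shared core this halogen change does not move the number. With bromo held constant, phenyl in place of hydroxymethyl gives a 7.2-fold higher number from compound 1 to compound 3 (0.86 log units; beyond the scatter), so the hydroxymethyl-to-phenyl change moves the number, whereas the halogen change does not. Nothing at hand explains this difference.

On these data alone, whether the halogen change would stay as small with hydroxymethyl on the core remains open. So does how an amine or a carboxylic acid would fare in place of the halogen.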